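Oxazole head group replacing the carbamoyl-furan in compound 1

The source may report more compounds than this note shows. Statements on the series, on what has been measured and on what is new or still open speak of the compounds shown alone.

Compound 1 `CNC(=O)c1ccc([C@H](C(=O)NC(C)C)N2C(=O)[C@@H](C3Cc4ccccc4C3)NC(=O)[C@H]2CC(C)C)o1` gives 39.8 nM in an assay on isolated protein for binding affinity to Oxytocin receptor (Homo sapiens) (on this read-out lower numbers stand for stronger inhibition and higher numbers for weaker inhibition), the highest number of the three measured compounds; compound 2 `Cc1nc([C@H](C(=O)N(C)C)N2C(=O)[C@@H](C3Cc4ccccc4C3)NC(=O)[C@H]2CC(C)C)cs1` gives 0.398 nM and compound 3 `Cc1nc([C@H](C(=O)N(C)C)N2C(=O)[C@@H](C3Cc4ccccc4C3)NC(=O)[C@H]2CC(C)C)c(C)o1` gives 3.16 nM in this assay. Compound 4 `Cc1nc([C@H](C(=O)NC(C)C)N2C(=O)[C@@H](C3Cc4ccccc4C3)NC(=O)[C@H]2CC(C)C)co1` differs from compound 1 in one place: a group of 6 heavy atoms (4 carbon, 1 nitrogen, 1 oxygen; one five-membered aromatic ring with 2 hetero atoms) in place of a group of 9 heavy atoms (6 carbon, 1 nitrogen, 2 oxygen; one five-membered aromatic ring with 1 hetero atom), on a saturated chain carbon bound to an amide-type nitrogen in a ring and a carbonyl carbon. For the measured compounds named here, no measured step covers this exact change; the only step available, a 7.9-fold higher number from compound 2 to compound 3 (0.90 log units; beyond the scatter), compares two heteroaryl groups on the same carbon, and both carry the dimethylamide rather than the isopropylamide of compound 1 and compound 4. Given that compound 3, the nearest measured oxazole, gives 3.16 nM, compound 4 is expected to sit closer to that number than to compound 1, so the estimated step is an 8.0-fold lower number from compound 1 to compound 4 (0.90 log units; beyond the scatter), a lower number. Compound 4 is therefore estimated at 5 nM, between 1 nM and 25 nM.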

Compound 4, inhibition constant: 1.26 nM
Compound 4: middle estimate off by 4.0-fold (0.60 log units), on the high side, and the stated range covers the measured number.
By their numbers in this assay, from the lowest: compound 2; then compound 4; then compound 3; then compound 1.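

With the isopropylamide held constant, 2-methyl-1,3-oxazol-4-yl in place of the carbamoyl-furan group, on a saturated chain carbon bound to an amide-type nitrogen in a ring and a carbonyl carbon, gives a 32-fold lower number from compound 1 to compound 4 (1.50 log units; beyond the scatter) in this assay. The head group at this position therefore matters with the isopropylamide too, not only with the dimethylamide of compound 2 and compound 3. Nothing at hand gives a reason for the step.

On these data alone, whether the step comes from the oxazole ring or from the loss of the methylamide stays open; a plain furan would separate the two. As far as these compounds go, how the isopropylamide compares with the dimethylamide on one and the same head group also stays open.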